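Shortening the chain from compound 3 to compound 4

The source may report more compounds than this note shows. Statements on the series, on what has been measured and on what is new or still open speak of the compounds shown alone.

In a functional assay on MCF7 cells (Homo sapiens) for inhibition, read by MTT assay, with stated times of 18 h and 4 h (a higher number here means a weaker inhibitor, a lower number a stronger inhibitor), compound 1 (`CCCCCCCCOP(=O)(O)OCCSC(=S)N1CCCC1`) gives 53000 nM and compound 3 (`CCCCCCCCCCOP(=O)(O)OCCSC(=S)N1CCCC1`) gives 70000 nM. For the measured compounds named here, these are the only two numbers and they sit within the scatter of each other, so compound 3 stands level with compound 1. Compound 2 (`CCCOP(=O)(O)OCCSC(=S)N1CCCCC1`) reads > 100000 nM, which is a limit of the assay and not a number.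

Going to compound 4 (`CCCOP(=O)(O)OCCSC(=S)N1CCCC1`) puts hydrogen in place of heptyl on a saturated chain carbon, three bonds along the chain from an oxygen on an unsaturated carbon. Going by the values given here, the only measured chain step is a 1.3-fold higher number from compound 1 to compound 3 (0.12 log units; within the scatter) and it covers a much smaller change, ethyl in place of hydrogen, so it sets no size for this one. The expected direction leans on the limit seen for compound 2. The estimated change is a 2.1-fold higher number from compound 3 to compound 4 (0.33 log units; beyond the scatter) in this assay, toward a weaker reading. For compound 4 the estimated value is 150000 nM with an expected range of 60000 nM to 300000 nM and a report of only a limit is quite possible.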

Compound 4, half-maximal inhibitory concentration: 73000 nM
The estimate for compound 4 lay 2.1-fold (0.31 log units) above the measured number; the range from low to high includes it.
By their numbers in this assay, from the lowest: compounds 1, 3 and 4 (each within the scatter of the next). At a limit, above all of these: compound 2.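

Hydrogen in place of heptyl at this position gives a 1.0-fold higher number from compound 3 to compound 4 (0.02 log units; within the scatter) in this assay, and hydrogen in place of pentyl gives a 1.4-fold higher number from compound 1 to compound 4 (0.14 log units; within the scatter) in the same assay. The earlier chain step covered only ethyl in place of hydrogen, whereas these much larger chain changes also leave the reading within the scatter, so chain length at this position shows no measurable effect across compounds 1, 3 and 4. Pyrrolidin-1-yl in place of piperidin-1-yl on the thiocarbonyl carbon gives an at least 1.3-fold lower number from compound 2 to compound 4 (0.13 log units; that floor lies within the scatter) and so cannot be sized, since the reading for compound 2 is a limit of the assay and not a number: the limit of > 100000 nM in this assay, at which 1 of the 4 values shown sits.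

On these data alone, it remains open whether a longer chain, or a chain ending in an amine or a carboxylic acid, would move the reading beyond the scatter. As far as these compounds go, the effect of a morpholin-4-yl group on the thiocarbonyl carbon also remains open.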